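This account rests on a few compounds, and the source may have more. Where it says the series, first, only, none or still open, it means among the compounds named here.

Working notes on the hydroxamic acid series.

Compound 1 `COc1cc(C(=O)NOCCCCCC(=O)NO)cc(OC)c1OC` carries three methoxy groups on the aromatic ring of its cap. In an assay on isolated protein for inhibition of histone deacetylase 4 (Homo sapiens) (a higher number here means a weaker inhibitor, a lower number a stronger inhibitor), compound 1 gives 93100 nM. Within the data shown here, this is the only plain number in the set: compound 1 stands alone on the scale, with the other entry sitting at a limit of the assay rather than a number. Compound 2 `CC(C)(C)c1cc(C(=O)NOCCCCCC(=O)NO)cc(C(C)(C)C)c1` reaches only the limit > 100000 nM in this assay, which is a limit and not a measured value. So far, then, the series is weak throughout, and one of the two entries sits at the limit of > 100000 nM in this assay, at which 1 of the 2 values shown sits.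

Compound 3 `COc1cc(OC)cc(C(=O)NOCCCCCC(=O)NO)c1` is the next member. The change from compound 1 is hydrogen in place of methoxy on an aromatic carbon. Among the measured compounds shown here, no measured pair of this kind exists in the set, so the size of the step can only be guessed. Given that compound 1 already gives the weak value of 93100 nM, the expectation is a step of a 1.2-fold higher number from compound 1 to compound 3 (0.07 log units; within the scatter) in this assay, with no change beyond the scatter required. Compound 3 is thus estimated at 110000 nM, within a range of 40000 nM to 300000 nM.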

Compound 3, inhibition constant: 49200 nM
Compound 3: the middle estimate sits 2.2-fold (0.35 log units) above what was measured, within the range that was stated.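

Hydrogen in place of methoxy, at the position para to a large group, gives a 1.9-fold lower number from compound 1 to compound 3 (0.28 log units; within the scatter) in this assay, and this is the only measured step in the series so far. The methoxy at this position is therefore not required for the weak inhibition seen with compound 1, since removing it produces no change beyond the scatter, and compound 3 stays in the same weak region of the scale with 49200 nM. Compound 2 is the one entry that remains a limit and not a number: the limit of > 100000 nM in this assay, at which 1 of the 3 values shown sits.

Among these compounds, only one kind of change has been read at this position, so it remains open whether a different group there, such as an amine or a carboxylic acid, would move the value beyond the scatter in this assay. Among the compounds shown here, also unresolved are the contribution of the two methoxy groups that remain on compound 3 and the effect of a longer chain between the cap and the hydroxamic acid, as no measured step yet covers either.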